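The source may hold more compounds than are shown below. What is called first, only, known or untested is meant among the compounds shown, and "the series" means these compounds.

Working notes on the series. In a functional assay on LS174T cells (Homo sapiens) for inhibition, with a stated time of 4 days, tested at 100 nM (a lower number here means a weaker effect, a higher number a stronger effect of the compound at the concentration tested), compound 1 `Fc1cccc(F)c1C#Cc1cnc(Cl)c2ccccc12` gives 0.8%, and compound 2 `Nc1ncc(C#Cc2c(F)cccc2F)c2ccccc12` gives 35.5%. Among the compounds with values here, compound 2 thus stands highest of the two numbers measured, with compound 1 nearest, and the only measured step is a number 34.7 percentage points higher from compound 1 to compound 2 (beyond the scatter). Compound 3 `CN(C)c1ncc(C#Cc2c(F)cccc2F)c2ccccc12` is not yet measured. It differs from compound 2 in one place: dimethylamino in place of amino on an aromatic carbon. Within the data shown here, the measured step from chloro to amino does not cover this change; it shows only that the group on this carbon of the shared core can move the read-out in this assay by a large amount, and no measured pair puts dimethylamino in place of amino. The expectation is therefore uncertain and drawn wide: a downward step of a number 23.5 percentage points lower from compound 2 to compound 3 (beyond the scatter) is expected, since the amino now replaced is the group whose arrival gave a number 34.7 percentage points higher from compound 1 to compound 2 (beyond the scatter). For compound 3 the estimated value in this assay is 12%, with a range from -5% to 38%.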

Compound 3, a percentage reported as inhibition, at one concentration (the size of the read-out at that concentration, not a potency): 81.7%
Beside the measured number, compound 3's estimate is 69.7 percentage points below it, outside the stated range (above it).
By their numbers in this assay, from the lowest: compound 1; then compound 2; then compound 3.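

In this assay the change on this aromatic carbon, next to the ring nitrogen, does not stop at amino: dimethylamino in place of amino gives a number 46.2 percentage points higher from compound 2 to compound 3 (beyond the scatter), a step larger than the one that chloro to amino gave. Measured against the chloro group, dimethylamino gives a number 80.9 percentage points higher from compound 1 to compound 3 (beyond the scatter), so the three groups at this one place span most of the read-out's range, in the order chloro, amino, dimethylamino. Nothing at hand accounts for this rise, so the gain stands as an observation only.

The compounds shown leave open whether methylamino would fall between amino and dimethylamino. They also leave open whether the read-out holds or drops with larger groups at this carbon, such as diethylamino or a pyrrolidine ring.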